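This account rests on a few compounds, and the source may have more. Where it says the series, first, only, none or still open, it means among the compounds named here.

Measured compounds:
- compound 1 `N=C(NC(=N)NC1CCCC1)Nc1ccc(C(F)(F)F)cc1`: 2500 nM in a functional assay on A2780 cells (Homo sapiens) for antiproliferative activity, read by MTT assay, with a stated time of 72 h; a higher number here means a weaker inhibitor, a lower number a stronger inhibitor
- compound 2 `CC(C)NC(=N)NC(=N)Nc1ccc(F)c(F)c1`: 26000 nM in this assay

Compound 1 stands at the lower of the two numbers; the gap to compound 2 lies beyond the usual scatter, so compound 1 is the stronger inhibitor of the pair. For the measured compounds named here, no step between the two is counted, as they differ in more than one place.

Compound 3 `CCN(CC)C(=N)NC(=N)Nc1ccc(C(F)(F)F)cc1` is not yet measured. Its change from compound 1 is diethylamino in place of cyclopentylamino on a carbon with a double bond to nitrogen. The shared core and the trifluoromethyl-bearing ring remain. Going by the values given here, no measured pair shows the effect of this change, so the direction is uncertain; a modest move toward a higher number is expected rather than a large one. The step of a 2.0-fold higher number from compound 1 to compound 3 (0.30 log units; within the scatter) is the estimated size. For compound 3 the expected value in this assay is 5000 nM, within 1500 nM to 20000 nM.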

Compound 3, half-maximal inhibitory concentration: 3800 nM
Compound 3: the middle estimate sits 1.3-fold (0.12 log units) above what was measured; low and high end bracket the measured number.
By their numbers in this assay, from the lowest: compounds 1 and 3 (each within the scatter of the next); then compound 2.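

In this assay, diethylamino in place of cyclopentylamino on a carbon with a double bond to nitrogen gives a 1.5-fold higher number from compound 1 to compound 3 (0.18 log units; within the scatter). For the compounds shown here, this is the first one-place comparison, and it shows that at this place the five-membered ring and the hydrogen-bond donor counted on cyclopentylamino can both be lost without a change that stands out from the scatter. No measurement at hand gives a reason for this result.

From the compounds shown here alone, whether a morpholine ring, a free amino group or a longer chain such as dipropylamino at this place would also stay within the scatter of compound 1 remains open. Compound 2 differs from compound 1 in more than one place, so the gap between their numbers cannot be assigned to any single group.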